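The compounds below may be only part of what the source reports. "The series", "measured", "known", "first", "only" and "open" are said of these compounds alone.

Compound 1 `O=S(=O)(Nc1ccc2oc(-c3ccccc3)nc2c1)c1ccc(Cl)c(Cl)c1` was tested in an assay on cells for inhibition of HSP60/HSP10 (Homo sapiens), with a stated time of 60 min; on this read-out higher numbers stand for weaker inhibition and lower numbers for stronger inhibition. In this assay compound 1 gives only a limit, > 100000 nM, so its true potency is not known as a number. Two related compounds were measured in the same way. Compound 2 `COc1ccc(S(=O)(=O)Nc2ccc(-c3nc4ccccc4o3)cc2)cc1` also reaches only the limit of the assay, > 100000 nM. Compound 3 `Cc1cccc(S(=O)(=O)Nc2ccc(-c3nc4ccccc4o3)cc2)c1` likewise stops at the limit, > 100000 nM. Within the data shown here, the one change between two measured compounds that alters a single place, a step that the two limits leave unreadable from compound 2 to compound 3, therefore cannot be read as a number in either direction. Taken together, the picture is simply (the limit of > 100000 nM in this assay, at which 3 of the 3 values shown sit).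

Compound 4 `O=S(=O)(Nc1ccc2oc(-c3ccccc3)nc2c1)c1ccccc1Cl` has not yet been measured. It differs from compound 1 in one way: 2-chlorophenyl in place of 3,4-dichlorophenyl on a sulfonyl sulfur. Among the measured compounds shown here, no measured step bears directly on this change: the only comparable step is hidden by the limits, and all three measured values sit at that same limit, so there is no readable size to lean on. The expectation for compound 4 is therefore that it stays at the limit as well, with the step of a number no higher from compound 1 to compound 4 (the limit leaves the size open) expected to be unreadable rather than a real gain or loss. On this basis compound 4 is estimated at 100000 nM, with a range from 30000 nM to 300000 nM.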

Compound 4, half-maximal inhibitory concentration: > 100000 nM
Compound 4: a limit, no number; the forecaster's own chance of this, stated with the estimate: 85%; the middle value sits exactly at the limit.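

Among these compounds, compound 1 and compound 4 both give a limit rather than a number, so the change from 3,4-dichlorophenyl to 2-chlorophenyl yields no step that can be read. The compounds shown leave open what structural change, if any, would give a measurable potency, with every result so far resting on the same point: the limit of > 100000 nM in this assay, at which 4 of the 4 values shown sit.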